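The compounds below may be only part of what the source reports. "The series", "measured", "known", "first", "only" and "open" are said of these compounds alone.

Measured so far:
- compound 1 `COc1ccc(/C=C\c2cc(OC)c(OC)c(OC)c2)cc1NC(=O)[C@H](C)NC(=O)[C@H](CCCNC(=N)N)NC(=O)[C@H](CCCCN)NC(=O)c1ccccc1`: > 100000 nM (a limit)
- compound 2 `COc1ccc(/C=C\c2cc(OC)c(OC)c(OC)c2)cc1NC(=O)[C@H](CO)NC(=O)[C@H](CCCNC(=N)N)NC(=O)[C@H](CCCNC(=N)N)NC(=O)c1ccccc1`: > 100000 nM (a limit)

Both entries come from an ADME assay on Huh-7 cells (Homo sapiens) for cytotoxicity, with a stated time of 24 h (on this read-out lower numbers stand for higher toxicity in this test and higher numbers for lower toxicity in this test), and neither is a number. Compound 2 stands at the limit of > 100000 nM in this assay, at which 2 of the 2 values shown sit, so its position is known only as a limit.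

The next compound, not yet measured, is compound 3 `COc1ccc(/C=C\c2cc(OC)c(OC)c(OC)c2)cc1NC(=O)[C@H](C)NC(=O)[C@H](CCCNC(=N)N)NC(=O)[C@H](CCCNC(=N)N)NC(=O)c1ccccc1`. Its difference from compound 2 is hydrogen in place of hydroxy on a saturated chain carbon, two bonds along the chain from an amide-type nitrogen and a carbonyl carbon. In words, this is hydrogen in place of hydroxy on a saturated chain carbon, two bonds along the chain from an amide-type nitrogen and a carbonyl carbon, which also reads as hydroxymethyl to methyl.

Going by the values given here, the series offers no measured step between compounds that differ in one place. Compound 1 already carries the methyl, and its reading of > 100000 nM is a limit. On that basis, no change beyond the usual scatter is expected in this assay, and a report at the same limit is the likeliest result. The estimated step of a number no higher from compound 2 to compound 3 (the limit leaves the size open) reflects that expectation. For compound 3 the expected value is 100000 nM, with an estimated range of 50000 nM to 200000 nM.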

Compound 3, half-maximal cytotoxic concentration: 111000 nM
Compound 3: middle estimate off by 1.1-fold (0.05 log units), on the low side, within the range that was stated.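

In this assay, no step can be read from compound 2 to compound 3 or from compound 1 to compound 3, as compound 1 and compound 2 are each reported only as a limit. The compounds shown leave open how large an effect hydroxymethyl to methyl has in this assay, and whether compound 3 truly differs from either partner.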